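A few compounds are considered here, and "the series" means these few. Any claim that something is new, unique, unknown or untested is made for them only; others in the source may bear on it.

Measured in an assay on CHO cells for displacement of a labelled ligand from adenosine receptor A3 (Homo sapiens), read by scintillation counting, tested at 10 uM; on this read-out lower numbers stand for less inhibition and higher numbers for more inhibition at the one concentration tested (going by the name of the read-out):

Compound 3, `COc1ccc(-c2sc(N)c(C(=O)c3ccc(Cl)cc3)c2CC(C)(C)C)cc1`: 2%
Compound 1, `CC(C)(C)Cc1c(-c2c(F)cccc2F)sc(N)c1C(=O)c1ccc(Cl)cc1`: 1%
Compound 2, `CC(C)(C)Cc1c(-c2ccc(Cl)c(Cl)c2)sc(N)c1C(=O)c1ccc(Cl)cc1`: 1%

All three compounds share one core and differ only in the aryl group attached to the five-membered ring next to the sulfur. On the numbers shown, compound 3 sits together with the other two: the step of a number 1 percentage points higher from compound 1 to compound 3 (within the scatter) and the step of a number 1 percentage points higher from compound 2 to compound 3 (within the scatter) are both within the scatter, so none of the three shows any inhibition worth the name, and no order among them can be read from these figures.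

Compound 4, `CC(C)(C)Cc1c(-c2cn[nH]c2)sc(N)c1C(=O)c1ccc(Cl)cc1`, is the next member of the series. It differs from compound 3 as follows: 1H-pyrazol-4-yl in place of 4-methoxyphenyl on an aromatic carbon. The two measured steps that bear on this change are the ones in which the same aryl position was varied, from compound 1 to compound 3 and from compound 2 to compound 3, and both were within the scatter. The expectation is therefore that the step of a number 1 percentage points higher from compound 3 to compound 4 (within the scatter) will stay within the scatter as well. Compound 4 is thus estimated to give 3%, somewhere between -6% and 14%.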

Compound 4, a percentage reported as inhibition, at one concentration (the size of the read-out at that concentration, not a potency): 1%
Estimate against measurement, compound 4: 2 percentage points above; the measured number falls inside the stated range.
By their numbers in this assay, from the lowest: compounds 1, 2, 4 and 3 (each within the scatter of the next).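

Until now this position, next to the ring sulfur, had carried only six-membered aromatic rings of carbon, whereas the 1H-pyrazol-4-yl brings a five-membered aromatic ring with 2 hetero atoms and 1 hydrogen-bond donor. Even this different ring leaves this assay flat: the read-out shows a number 1 percentage points lower from compound 3 to compound 4 (within the scatter) and no change at the digits printed from compound 2 to compound 4 (within the scatter) and no change at the digits printed from compound 1 to compound 4 (within the scatter) so the series stays without inhibition worth the name across both ring types. No measurement at hand offers an explanation for this.

Open, as far as these compounds go, is whether a group other than an aromatic ring at this position, such as a carboxylic acid or a primary amine on a short carbon chain, would move the number. Also open, from the compounds shown here alone, is whether replacing the neopentyl group with a longer chain, or changing the amino group, would produce any inhibition on this shared core.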